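Amide nitrogen substituent in the thiophenylmethyl aryloxyacetamide series

The compounds below may be only part of what the source reports. "The series", "measured", "known", "first", "only" and "open" are said of these compounds alone.

Compound 3 `Cc1ccc(OCC(=O)N(Cc2cccs2)C(C)C)cc1` gives the lowest number of the three measured, 70 nM in an assay on HEK293 cells for agonist activity at transient receptor potential cation channel subfamily M member 8 (Homo sapiens), read by fluorescence and calcium flux, with a stated time of 15 min; on this read-out lower numbers stand for an effect already at smaller amounts and higher numbers for an effect only at larger amounts of compound. Compound 1 `Cc1ccc(OCC(=O)N(Cc2cccs2)c2ccn(C)n2)cc1` gives 855 nM, and compound 2 `Cc1ccc(OCC(=O)N(Cc2cccs2)C2CCCCC2)cc1` gives 40000 nM. The steps of a 570-fold lower number from compound 2 to compound 3 (2.76 log units; beyond the scatter) and a 12-fold lower number from compound 1 to compound 3 (1.09 log units; beyond the scatter) show that what sits on the amide nitrogen moves this read-out strongly. Compound 4 `Cc1ccc(OCC(=O)N(C)Cc2cccs2)cc1` carries methyl in place of isopropyl on an amide-type nitrogen. Among the compounds with values here, no measured step goes from isopropyl to a smaller group, so the direction cannot be read off directly; the large shifts seen on this nitrogen suggest a step beyond the scatter is likely, and a higher number is judged somewhat more probable than a lower one. For compound 4 the expected value is 250 nM, range 40 nM to 2000 nM, an estimated step of a 3.6-fold higher number from compound 3 to compound 4 (0.55 log units; beyond the scatter).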

Compound 4, half-maximal effective concentration: 400 nM
The estimate for compound 4 lay 1.6-fold (0.20 log units) below the measured number; measured number inside the range.
By their numbers in this assay, from the lowest: compound 3; then compound 4; then compound 1; then compound 2.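

Going down from isopropyl to methyl also raises the number, with a 5.7-fold higher number from compound 3 to compound 4 (0.76 log units; beyond the scatter) on this amide-type nitrogen, so both methyl and cyclohexyl read higher than isopropyl and the series does not run in one direction with the alkyl group. The cyclohexyl end is far the worse, given a 100-fold lower number from compound 2 to compound 4 (2.00 log units; beyond the scatter) here, and methyl also reads lower than 1-methyl-1H-pyrazol-3-yl, with a 2.1-fold lower number from compound 1 to compound 4 (0.33 log units; beyond the scatter) as a modest step. Nothing available bears on why these numbers move.

Going by these compounds, how ethyl, cyclopropyl or tert-butyl would read on this nitrogen stays open. So does the effect of a longer chain ending in an amine or a carboxylic acid.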